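The compounds below may be only part of what the source reports. "The series", "measured", "known", "first", "only" and "open" are said of these compounds alone.

Measured compounds:
compound 1 `CC(C)[C@H](C[C@H]1OC(=O)NC1=O)c1ccc(-c2ccc3cccc(F)c3c2)[nH]c1=O` gives 35400 nM
compound 2 `O=C1NC(=O)/C(=C/C(c2ccc(-c3ccc4cccc(F)c4c3)[nH]c2=O)C2CC2)O1` gives 30800 nM
compound 3 `CC(C)/C(=C1/SC(=O)NC1=O)c1ccc(-c2ccc3cccc(F)c3c2)[nH]c1=O` gives 23300 nM

These three compounds share one core and differ only in the group hanging from the saturated chain. In a physicochemical assay for solubility, in phosphate buffer, measured as kinetic solubility (a lower number here means a less soluble compound, a higher number a more soluble compound), compound 1 has the highest of the three numbers, but the gaps to the others are small: compound 2 sits closest to it, and compound 3 is furthest away, yet both gaps lie within the usual scatter of repeated measurements. On these numbers, then, the three compounds cannot be told apart in this assay.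

Compound 4 `CC(C)[C@H](C[C@H]1SC(=O)NC1=O)c1ccc(-c2ccc3cccc(F)c3c2)[nH]c1=O` has not yet been measured. It differs from compound 1 in one place: 2,4-dioxo-1,3-thiazolidin-5-yl in place of 2,4-dioxo-1,3-oxazolidin-5-yl on a saturated chain carbon, two bonds along the chain from an aromatic carbon. Among the compounds with values here, nothing among the measured compounds reports a direct step of this kind, since compound 3 carries the thiazolidinedione on a double bond rather than on a saturated carbon and is a different comparison. What the three values show is that changes in this part of the molecule have so far stayed within the scatter, and the step from compound 1 to compound 4 is expected to do the same, at most a slight drift downward, a 1.3-fold lower number from compound 1 to compound 4 (0.10 log units; within the scatter). On that basis compound 4 is estimated to give 28000 nM in this assay, with a likely range from 14000 nM to 56000 nM.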

Compound 4, solubility: 31200 nM
For compound 4 the middle estimate is 1.1-fold (0.05 log units) below the measured one, and the stated range covers the measured number.
By their numbers in this assay, from the lowest: compounds 3, 2, 4 and 1 (each within the scatter of the next).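

Within the data shown here, compound 1 and compound 4 are the first pair here that differ in one place only, so this exchange can be read directly, which no earlier pair allowed. In this assay, replacing 2,4-dioxo-1,3-oxazolidin-5-yl with 2,4-dioxo-1,3-thiazolidin-5-yl on a saturated chain carbon, two bonds along the chain from an aromatic carbon, gives a 1.1-fold lower number from compound 1 to compound 4 (0.05 log units; within the scatter), a step within the scatter, so the two rings cannot be told apart at this position in this assay. No separate measurement is available to account for this result.

As far as these compounds go, it remains open whether a more different group at this chain carbon, such as a carboxylic acid or an amine in place of the ring, would produce a step beyond the scatter. Among these compounds, this single pair also speaks for only one core and one assay, so it is unknown whether the same exchange would remain as small on another core or in a different kind of measurement.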